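A few compounds are considered here, and "the series" means these few. Any claim that something is new, unique, unknown or untested is made for them only; others in the source may bear on it.

Measured compounds:
- compound 1, `CN1CCN([C@@H]2CN[C@H](C(=O)N3CCSC3)C2)CC1`, 81.1 nM in an assay on a cell-free system (plasma) for inhibition of Dipeptidyl peptidase 4 (Rattus norvegicus), read by fluorescence; on this read-out lower numbers stand for stronger inhibition and higher numbers for weaker inhibition
- compound 2, `O=C([C@@H]1C[C@H](N2CCN(c3ccccc3Cl)CC2)CN1)N1CCSC1`, 10.9 nM in this assay

Compound 2 holds the lowest of the two numbers in this assay; the nearest is compound 1, reached by the step of a 7.4-fold lower number from compound 1 to compound 2 (0.87 log units; beyond the scatter). Compound 3, `O=C([C@@H]1C[C@H](N2CCN(c3cccc(Cl)c3)CC2)CN1)N1CCSC1`, differs from compound 2 only by 3-chlorophenyl in place of 2-chlorophenyl on an amine nitrogen in a ring. Within the data shown here, no measured step touches this change; the one step known concerns the aryl group as a whole, not where its chlorine sits, so it gives no direction. For compound 3 in this assay a step of about a 1.1-fold higher number from compound 2 to compound 3 (0.04 log units; within the scatter) is expected, not beyond the scatter. Compound 3 is estimated at 12 nM, between 4 nM and 40 nM.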

Compound 3, half-maximal inhibitory concentration: 7.2 nM
Beside the measured number, compound 3's estimate is 1.7-fold (0.22 log units) above it; low and high end bracket the measured number.
By their numbers in this assay, from the lowest: compounds 3 and 2 (each within the scatter of the next); then compound 1.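

3-Chlorophenyl in place of 2-chlorophenyl gives a 1.5-fold lower number from compound 2 to compound 3 (0.18 log units; within the scatter) in this assay, so this position on the aryl ring does not separate these two chlorine placements. 3-Chlorophenyl in place of methyl gives an 11-fold lower number from compound 1 to compound 3 (1.05 log units; beyond the scatter), so the gain over methyl is not confined to 2-chlorophenyl. No available data bear on the reason for this result.

Open, as far as these compounds go, is whether unsubstituted phenyl matches either chlorophenyl compound. Also open, from the compounds shown here alone, is whether fluorine or methoxy in place of the chlorine would read the same.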